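Removing the Ring Nitrogen: From Quinoline to Naphthalene

The compounds below may be only part of what the source reports. "The series", "measured", "known", "first", "only" and "open" are said of these compounds alone.

Of the compounds shown here, three sharing one core have been measured in a physicochemical assay for solubility, read by HPLC, in phosphate buffer, measured as thermodynamic solubility, with a stated time of 24 h, at pH 7.4; a lower number here means a less soluble compound, a higher number a more soluble compound. Compound 1 `C[C@@H]1CN([C@@H](C)CO)C(=O)c2cccc(NC(=O)Nc3cncc4ccccc34)c2O[C@H]1CN(C)S(=O)(=O)c1ccc2c(c1)OCCO2` gives 84900 nM, compound 2 `C[C@@H]1CN([C@@H](C)CO)C(=O)c2cccc(NC(=O)N(C)c3cccc4ccccc34)c2O[C@H]1CN(C)S(=O)(=O)c1ccc2c(c1)OCCO2` gives 11200 nM, and compound 3 `C[C@@H]1CN([C@@H](C)CO)C(=O)c2cccc(NC(=O)Nc3ccnc4ccccc34)c2O[C@H]1CN(C)S(=O)(=O)c1ccc2c(c1)OCCO2` gives 30300 nM. Compound 3 therefore stands second highest of the three, with compound 2 nearest to it and compound 1 furthest from it.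

Compound 4 `C[C@@H]1CN([C@@H](C)CO)C(=O)c2cccc(NC(=O)Nc3cccc4ccccc34)c2O[C@H]1CN(C)S(=O)(=O)c1ccc2c(c1)OCCO2` differs from compound 3 in one place: naphthalen-1-yl in place of quinolin-4-yl on an amide-type nitrogen. The ring that leaves carries one hydrogen-bond acceptor, the ring that enters carries none.

Going by the values given here, two measured steps bear on this change. The step of a 2.7-fold higher number from compound 2 to compound 3 (0.43 log units; beyond the scatter) is the closest comparison, though compound 2 also carries a methyl group on the amide-type nitrogen that compound 4 does not. The step of a 2.8-fold lower number from compound 1 to compound 3 (0.45 log units; beyond the scatter) shows that moving the ring nitrogen within the bicyclic group already shifts the number modestly. Taken together, the expectation for compound 4 is a modest step downward in this assay, a 2.5-fold lower number from compound 3 to compound 4 (0.40 log units; beyond the scatter), landing close to where compound 2 stands.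

Compound 4 is thus estimated at 12000 nM, with a likely range from 5000 nM to 30000 nM.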

Compound 4, solubility: 100 nM
For compound 4 the middle estimate is 120-fold (2.08 log units) above the measured one; the measured number lies below the stated range.
By their numbers in this assay, from the lowest: compound 4; then compound 2; then compound 3; then compound 1.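

In this assay, naphthalen-1-yl in place of quinolin-4-yl on the amide-type nitrogen gives a 300-fold lower number from compound 3 to compound 4 (2.48 log units; beyond the scatter) and in place of isoquinolin-4-yl gives an 850-fold lower number from compound 1 to compound 4 (2.93 log units; beyond the scatter) in the same read-out. These steps are far larger than the modest shift seen when only the ring nitrogen moved, so at this position the numbers separate most sharply between the rings that carry a nitrogen and the ring of carbon only. Yet a carbon-only ring does not settle the number alone: hydrogen in place of methyl on that same nitrogen gives a 110-fold lower number from compound 2 to compound 4 (2.05 log units; beyond the scatter) and so compound 2, which also carries naphthalen-1-yl, goes against any simple rule based on the ring. The data shown offer no measurement that explains these large steps.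

On these data alone, what a methyl on the amide-type nitrogen would do with quinolin-4-yl or isoquinolin-4-yl in place stays open. Also open, as far as these compounds go, is where the number would fall with a single phenyl ring on that nitrogen, or with naphthalen-1-yl carrying an amine or a carboxylic acid.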